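Extending the chain from compound 3 to compound 4

The compounds below may be only part of what the source reports. "The series", "measured", "known", "first", "only" and "open" are said of these compounds alone.

For the measured compounds named here, in a functional assay on MGC-803 cells (Homo sapiens) for antiproliferative activity, read by MTT assay, with a stated time of 48 h (on this read-out lower numbers stand for stronger inhibition and higher numbers for weaker inhibition), compound 1 `CCCCCCCCn1cc(COC[C@@H]2OC[C@H](N)[C@@H]2O)nn1` gives 70400 nM as the only true number so far. Compound 2 `CCCCCCCn1cc(COC[C@@H]2OC[C@H](N)[C@H]2O)nn1` shows > 128000 nM as a limit of the assay. Compound 3 `CCCCCCCCn1cc(COC[C@@H]2OC[C@H](N)[C@H]2O)nn1` also shows > 128000 nM as a limit and not a number. Its place in the series is thus the limit of > 128000 nM in this assay, at which 2 of the 3 values shown sit, and nothing finer.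

Compound 4 `CCCCCCCCCCn1cc(COC[C@@H]2OC[C@H](N)[C@H]2O)nn1` follows from compound 3 through ethyl in place of hydrogen on a saturated chain carbon, eight bonds along the chain from an aromatic nitrogen and amounts to ethyl in place of hydrogen on a saturated chain carbon, eight bonds along the chain from an aromatic nitrogen.

Going by the values given here, two measured steps bear on this change, and neither sizes it. The change of configuration at a saturated ring carbon gives an at least 1.8-fold higher number from compound 1 to compound 3 (0.25 log units; that floor lies within the scatter) and so shows no effect of configuration beyond the scatter. Among the compounds with values here, the one chain step, methyl in place of hydrogen, is a step that the two limits leave unreadable from compound 2 to compound 3 and gives no direction.

A move toward a lower number is expected only tentatively, and compound 1 at 70400 nM sets the likely scale. The expected step is an at least 2.1-fold lower number from compound 3 to compound 4 (0.32 log units; beyond the scatter) and remains a loose estimate. For compound 4 the estimated value is 60000 nM with an expected range of 22000 nM to 128000 nM and a reading at the limit remains possible.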

Compound 4, half-maximal inhibitory concentration: 57400 nM
Compound 4: middle estimate off by 1.0-fold (0.02 log units), on the high side; the measured number falls inside the stated range.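

In this assay, for the compounds shown here, this chain position now gives a readable result: ethyl in place of hydrogen on a saturated chain carbon, eight bonds along the chain from an aromatic nitrogen, gives an at least 2.2-fold lower number from compound 3 to compound 4 (0.34 log units; beyond the scatter), the first step to clear the scatter. The larger chain step points the same way with an at least 2.2-fold lower number from compound 2 to compound 4 (0.34 log units; beyond the scatter), while the methyl step between compound 2 and compound 3 cannot be read, since both of its ends are limits: the limit of > 128000 nM in this assay, at which 2 of the 4 values shown sit.
With the configuration of compound 3 kept, the chain change alone is enough to bring a true number out of that limit, although both new steps give only a floor and not a full size.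

As far as these compounds go, whether a longer chain than that of compound 4 lowers the number further remains open, and two chain steps of this kind do not yet make a trend. Also open, from the compounds shown here alone, is what the same ethyl change does on the ring-carbon configuration of compound 1, and what a carboxylic acid in place of ethyl would do.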